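Replacing a methylphenyl with a methylpyrazolyl on a shared core

This account rests on a few compounds, and the source may have more. Where it says the series, first, only, none or still open, it means among the compounds named here.

Compound 1, `Nc1cccc(Nc2cc(Cl)cc(Cl)c2)n1`, in an assay on cells for inhibition of S-adenosylmethionine decarboxylase proenzyme (Homo sapiens), read by mass spectrometry, at pH 7.2 (on this read-out higher numbers stand for weaker inhibition and lower numbers for stronger inhibition), gives > 180000 nM, which is a limit of the assay.
Compound 2, `Cc1ccc(-c2cc(Cl)cc(Nc3cc(C)nc(N)n3)c2)cc1`, in this assay gives > 63000 nM, also a limit.
Compound 3, `Cc1cc(Nc2cc(Cl)cc(-c3ccc(C(F)(F)F)cc3)c2)nc(N)n1`, in this assay gives > 21000 nM, again a limit.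

Compound 2 stands at a limit in this assay, and since the other two values shown are limits as well, its place among the three cannot be read. Going by the values given here, the only measured step, a step that the two limits leave unreadable from compound 2 to compound 3, has both of its ends at limits, so its size is not readable. Compound 4, `Cc1cc(Nc2cc(Cl)cc(-c3cnn(C)c3)c2)nc(N)n1`, differs from compound 2 by 1-methyl-1H-pyrazol-4-yl in place of 4-methylphenyl on an aromatic carbon. Among the compounds with values here, no measured step bears on this change, and the one step that exists gives no readable size, so the account has nothing to set an expected direction. Compound 4 is therefore expected to stay near where compound 2 stands, with a step that the limit leaves unreadable from compound 2 to compound 4 that is estimated to be none beyond the scatter. Compound 4 is estimated at 100000 nM, in a range from 20000 nM to 500000 nM, most likely reported again only as a limit.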

Compound 4, half-maximal inhibitory concentration: > 180000 nM
Compound 4 ended at the assay's limit (the forecaster's own chance of this, stated with the estimate: 80%); middle value at least 1.8-fold (0.25 log units) away from the limit.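

Compound 2 and compound 4 both stand at limits in this assay, and the step between them cannot be read. The compounds shown leave open how 1-methyl-1H-pyrazol-4-yl and 4-methylphenyl compare on the shared core, as none of them has a value that is more than a limit.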